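A few compounds are considered here, and "the series" means these few. Any claim that something is new, unique, unknown or untested is made for them only; others in the source may bear on it.

Compound 1 `CN(C(=O)NC(=O)c1ccc(Cl)cc1Cl)c1nc(C(F)(F)F)c(C(=O)N/N=C/c2cccc(C(F)(F)F)c2)s1` stands second highest of three numbers in a functional assay on HeLa cells (Homo sapiens) for inhibition, read by MTT assay, with a stated time of 72 h (on this read-out lower numbers stand for stronger inhibition and higher numbers for weaker inhibition), where compound 1 gives 9.6 ug/mL. Compound 2 `CN(C(=O)NC(=O)c1c(F)cccc1F)c1nc(C(F)(F)F)c(C(=O)N/N=C/c2cccc(C(F)(F)F)c2)s1` gives 21.6 ug/mL, and compound 3 `CN(C(=O)NC(=O)c1ccc(C(F)(F)F)cc1)c1nc(C(F)(F)F)c(C(=O)N/N=C/c2cccc(C(F)(F)F)c2)s1` gives 6.2 ug/mL. Of the steps among them, a 2.3-fold higher number from compound 1 to compound 2 (0.35 log units; beyond the scatter) and a 3.5-fold lower number from compound 2 to compound 3 (0.54 log units; beyond the scatter) lie beyond the scatter, while a 1.5-fold lower number from compound 1 to compound 3 (0.19 log units; within the scatter) lies within it. All three steps swap the group on a carbonyl carbon. Compound 4 `CN(C(=O)NC(=O)c1ccc(Cl)cc1Cl)c1nc(C(F)(F)F)c(C(=O)N/N=C/c2ccccc2C(F)(F)F)s1` changes a different place: 2-(trifluoromethyl)phenyl in place of 3-(trifluoromethyl)phenyl on a carbon with a double bond to nitrogen. For the measured compounds named here, no measured step touches that position, so none bears directly on it; the carbonyl-side changes were at most modest. The step of no change at the digits printed from compound 1 to compound 4 (within the scatter) is therefore expected to stay within the scatter, with no set direction. For compound 4 the estimate in this assay is 9.6 ug/mL, ranging from 4 ug/mL to 23 ug/mL.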

Compound 4, half-maximal inhibitory concentration: 9 ug/mL
Beside the measured number, compound 4's estimate is 1.1-fold (0.03 log units) above it, within the range that was stated.
By their numbers in this assay, from the lowest: compounds 3, 4 and 1 (each within the scatter of the next); then compound 2.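

With 2-(trifluoromethyl)phenyl in place of 3-(trifluoromethyl)phenyl on a carbon with a double bond to nitrogen, this assay shows a 1.1-fold lower number from compound 1 to compound 4 (0.03 log units; within the scatter). For the compounds shown here, this is the first reading at this place, and on the 2,4-dichlorophenyl background the two groups are not told apart. No measurement available here offers an explanation for this result. Still open, on these data alone, is whether an unsubstituted phenyl, a pyridine or a carboxylic acid-bearing phenyl at this place would hold the read-out. Also open, as far as these compounds go, is whether the same swap behaves alike with the 4-(trifluoromethyl)phenyl or 2,6-difluorophenyl group on the carbonyl carbon.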